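Methoxy-bearing chromones and a cytotoxicity limit

A few compounds are considered here, and "the series" means these few. Any claim that something is new, unique, unknown or untested is made for them only; others in the source may bear on it.

Measured compounds:
- compound 1, `COC(=O)c1c(-c2ccc([N+](=O)[O-])cc2)oc2ccccc2c1=O`: > 25 ug/mL
- compound 2, `COC(=O)c1c(-c2ccc([N+](=O)[O-])cc2)oc2cc(OC)ccc2c1=O`: > 25 ug/mL
- compound 3, `COc1ccc2c(=O)cc(-c3cc(OC)c(OC)c(OC)c3)oc2c1`: > 25 ug/mL

In a functional assay on A549 cells (Homo sapiens) for cytotoxicity, read by MTT assay, with a stated time of 6 days (on this read-out lower numbers stand for an effect already at smaller amounts and higher numbers for an effect only at larger amounts of compound), compound 1 gives only a limit of the assay, > 25 ug/mL. Compound 2 also reaches only a limit, > 25 ug/mL. Compound 3 likewise stops at a limit, > 25 ug/mL. Compound 2 differs from compound 1 by methoxy in place of hydrogen on an aromatic carbon, and the step that the two limits leave unreadable from compound 1 to compound 2 cannot be read, since both ends are limits; the one thing shared by all three is the limit of > 25 ug/mL in this assay, at which 3 of the 3 values shown sit.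

Compound 4, `COc1cc(-c2cc(=O)c3ccc(OC)c(OC)c3o2)cc(OC)c1OC`, has not yet been measured. It differs from compound 3 by methoxy in place of hydrogen on an aromatic carbon. This is the same kind of change as that from compound 1 to compound 2, though not the same: in compound 4 the new group sits ortho to a fused ring and ortho to a methoxy group, whereas in compound 2 it sits para to a fused ring. How the core of compound 3 differs from that of compound 1 is not broken down here.

With every measured value a limit, the expected step that the limit leaves unreadable from compound 3 to compound 4 is an estimate with little to stand on. For compound 4 the value is expected to be about 40 ug/mL in this assay, between 12 ug/mL and 120 ug/mL, most likely again reported as a limit, because compound 3 itself gives > 25 ug/mL.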

Compound 4, concentration for half-maximal effect: > 25 ug/mL
Compound 4 ended at the assay's limit; the forecaster's own chance of this, stated with the estimate: 75%; the middle value lies beyond the limit too.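

Compound 3 and compound 4 both stop at a limit of the assay rather than at a number, so the size of the step between them cannot be read. All four compounds share one result: the limit of > 25 ug/mL in this assay, at which 4 of the 4 values shown sit.

The compounds shown leave open whether methoxy in place of hydrogen on an aromatic carbon changes the effect at all in this assay.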